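The source may report more compounds than this note shows. Statements on the series, on what has been measured and on what is new or still open speak of the compounds shown alone.

Three compounds sharing a vinyl sulfone bridge between a methoxy-bearing benzene ring and a halogenated pyridine ring have been tested in an ADME assay on BV-2 cells (Mus musculus) for cytotoxicity, with a stated time of 24 h, tested at 50 uM; a lower number here means a stronger effect, a higher number a weaker effect of the compound at the concentration tested. Compound 1, `COc1cccc(S(=O)(=O)/C=C/c2ncccc2F)c1`, gives 97.4% in this assay. Compound 2, `COc1cccc(S(=O)(=O)/C=C/c2ncccc2Cl)c1`, differs from compound 1 by one change, (chloro in place of fluoro on an aromatic carbon), and in this assay compound 2 gives 82.2%. That change made a number 15.2 percentage points lower from compound 1 to compound 2 (beyond the scatter).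

Compound 3, `COc1ccc(S(=O)(=O)/C=C/c2ncccc2F)cc1`, has the same atoms as compound 1, joined differently; the difference between the two cores is not broken down here. In this assay compound 3 gives 86.6%. Its value and that of compound 2 lie within the usual scatter of each other, so no order between those two can be read. Against compound 1, the value of compound 3 is lower by more than the scatter.

Compound 4, `COc1ccc(S(=O)(=O)/C=C/c2ncccc2Cl)cc1`, has not yet been measured. Within the data shown here, it differs from compound 3 by chloro in place of fluoro on an aromatic carbon, which is the same change as the one from compound 1 to compound 2, at the same place in the molecule. The expected step in this assay is a number 13.6 percentage points lower from compound 3 to compound 4 (beyond the scatter), and that expectation rests on the earlier step of a number 15.2 percentage points lower from compound 1 to compound 2 (beyond the scatter), applied to the value of compound 3, allowing for the fact that one prior example is a thin basis. Compound 4 is therefore estimated to give 73%, most likely between 60% and 86%.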

Compound 4, a percentage reported as activity, at one concentration (the size of the read-out at that concentration, not a potency): 89.8%
Compound 4: the middle estimate sits 16.8 percentage points below what was measured; measured number above the stated range.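

On the core of compound 3, putting chloro in place of fluoro gives a number 3.2 percentage points higher from compound 3 to compound 4 (within the scatter) in this assay, so this swap leaves no readable difference between the two compounds on that core. The swap is the same and sits at the same place on the ring, yet its result depends on the core it is made on, so the step seen on one core cannot simply be carried over to the other: the same change on two cores in this assay, a number 15.2 percentage points lower (beyond the scatter) from compound 1 to compound 2 and a number 3.2 percentage points higher (within the scatter) from compound 3 to compound 4, 18.4 percentage points apart, beyond the scatter of two such steps What this does not show is why the two cores respond differently, or which of the two results is the more typical for this series, since two pairs of compounds in a single assay can support no general rule.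

The compounds shown leave open how each core would respond at this place to a group other than a halogen, such as a methyl, a nitrile or an amine. They also leave open what would happen if the methoxy group gave way to a hydroxyl or a carboxylic acid, and whether the difference between the two cores would persist with such groups.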